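This account rests on a few compounds, and the source may have more. Where it says the series, first, only, none or still open, it means among the compounds named here.

Measured compounds:
compound 1 `COC(=O)c1ccc(NCc2cncn2Cc2ccc([N+](=O)[O-])cc2)cc1-c1ccccc1` — > 10000 nM
compound 2 `c1ccc(-c2ccc(Cn3cncc3CNc3ccc(-c4cncs4)c(-c4ccccc4)c3)cc2)cc1` — > 1000 nM
compound 3 `O=[N+]([O-])c1ccc(Cn2cncc2CNc2cccc(-c3ccccc3)c2)cc1` — 10000 nM

In a toxicity assay on NIH3T3 cells (Mus musculus) for cytotoxicity, read by resazurin assay (a higher number here means that more compound is needed for the effect, a lower number that less compound is needed), compound 1 gives > 10000 nM, which is a limit of the assay rather than a number. Compound 2 likewise gives only a limit, > 1000 nM. Compound 3 gives a number, 10000 nM. Among the measured compounds shown here, the one measured step, a number no higher from compound 1 to compound 3 (the limit leaves the size open), concerns hydrogen in place of methoxycarbonyl on an aromatic carbon and has no readable size.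

Compound 4 `COC(=O)c1ccc(NCc2cncn2Cc2ccccc2[N+](=O)[O-])cc1-c1ccccc1` differs from compound 1 by 2-nitrophenyl in place of 4-nitrophenyl on a saturated chain carbon bound to an aromatic nitrogen. For the measured compounds named here, no measured step touches this change, so no direction is supported. The step of a number no higher from compound 1 to compound 4 (the limit leaves the size open) is expected to stay within the scatter. Compound 4 is therefore estimated at 10000 nM, in a range from 3000 nM to 30000 nM, quite possibly again only as a limit.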

Compound 4, half-maximal effective concentration: 10000 nM
For compound 4 middle estimate and measured number coincide at the digits printed; low and high end bracket the measured number.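

Compound 4 is the first compound shown with a change at this place, 2-nitrophenyl in place of 4-nitrophenyl, and in this assay compound 4 gives 10000 nM, a number rather than a limit. This change gives a number no higher from compound 1 to compound 4 (the limit leaves the size open). So the 2-nitrobenzyl compound can be placed on the scale, and cell toxicity appears only at a concentration as high as that number. Compound 1 stands only at a limit, so the size of this step cannot be read: the limit of > 10000 nM in this assay, at which 1 of the 4 values shown sits.

As far as these compounds go, what a carboxylic acid or an amine in place of the nitro group would give stays open. Also open, from the compounds shown here alone, is whether the same shift of the nitro group would give a readable difference on the core of compound 3.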